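Shortening the chain of compound 2 to a methyl

The compounds below may be only part of what the source reports. "The series", "measured", "known", "first", "only" and "open" are said of these compounds alone.

Compound 1 `COc1ncc(-c2ccc3nc(NC(=O)NCC(=O)N4CCCCC4)nn3c2)cc1NS(=O)(=O)c1ccc(F)cc1`: 2060 nM
Compound 2 `COc1ncc(-c2ccc3nc(NC(=O)NCCN4CCN(C)CC4)nn3c2)cc1NS(=O)(=O)c1ccc(F)cc1`: 1050 nM

Within the data shown here, in a functional assay on A549 cells (Homo sapiens) for cytotoxicity, read by MTT assay, with a stated time of 72 h (on this read-out higher numbers stand for weaker inhibition and lower numbers for stronger inhibition), compound 2 gives 1050 nM, which lies within the usual scatter of compound 1, the only other measured compound, so the two cannot be ranked. Compound 3 `CNC(=O)Nc1nc2ccc(-c3cnc(OC)c(NS(=O)(=O)c4ccc(F)cc4)c3)cn2n1` keeps the shared core and alters only the chain: hydrogen in place of (4-methylpiperazin-1-yl)methyl on a saturated chain carbon bound to an amide-type nitrogen. Put simply, hydrogen stands in place of (4-methylpiperazin-1-yl)methyl on a saturated chain carbon bound to an amide-type nitrogen, which turns 2-(4-methylpiperazin-1-yl)ethyl into methyl. Among the measured compounds shown here, the one measured step that bears on this, a 2.0-fold lower number from compound 1 to compound 2 (0.29 log units; within the scatter), also exchanged a group at that place and stayed within the scatter. It swapped one large group for another, however, so it is only thin evidence for removing the group. No clear change in either direction is expected, and the estimated step is a 1.2-fold lower number from compound 2 to compound 3 (0.07 log units; within the scatter). Compound 3 is expected at 900 nM, with an estimated range of 220 nM to 3500 nM.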

Compound 3, half-maximal inhibitory concentration: 230 nM
The estimate for compound 3 lay 3.9-fold (0.59 log units) above the measured number, and the stated range covers the measured number.
By their numbers in this assay, from the lowest: compound 3; then compounds 2 and 1 (each within the scatter of the next).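

In this assay, taking away the whole (4-methylpiperazin-1-yl)methyl group on a saturated chain carbon bound to an amide-type nitrogen gives a 4.6-fold lower number from compound 2 to compound 3 (0.66 log units; beyond the scatter) and so, unlike the earlier exchange of one large group for another, produces a change beyond the scatter. Hydrogen in place of (piperidin-1-yl)carbonyl at the same place gives a 9.0-fold lower number from compound 1 to compound 3 (0.95 log units; beyond the scatter), so the two large groups, which cannot be ranked against each other, both go with higher numbers than the plain methyl end, and this place does not need a large group for the lower number to appear. No measurement shown here explains this difference.

From the compounds shown here alone, it remains open whether the number keeps falling with any small end or depends on the methyl itself. An ethyl group, or a short chain ending in a dimethylamine or a carboxylic acid, would help to show whether chain length or the group at its end matters more.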